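A Crown-Ether Ester Swaps Its Acyl Chain

This account rests on a few compounds, and the source may have more. Where it says the series, first, only, none or still open, it means among the compounds named here.

Compound 1 `O=C(CCCCCc1ccccc1)OCC1COCCOCCOCCOCCOCCO1` is an ester in which a 5-phenylpentyl chain sits on the carbonyl carbon of the shared core. It was tested in a functional assay on WiDr cells (Homo sapiens) for inhibition, read by sulforhodamine B assay, with a stated time of 48 h; on this read-out higher numbers stand for weaker inhibition of growth and lower numbers for stronger inhibition of growth. In this assay compound 1 gives only a limit of the method, > 100000 nM, and not a number. Compound 2 `O=C(CCCCC1CCCCC1)OCC1COCCOCCOCCOCCO1`, a close relative on a similar core, was measured alongside it. Compound 2 likewise reaches only the limit, > 100000 nM. Both measured values therefore sit at the same limit (the limit of > 100000 nM in this assay, at which 2 of the 2 values shown sit), and neither shows measurable inhibition of growth, so compound 1 stands nowhere apart from compound 2 on the numbers shown.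

Compound 3 `CC(C)=CC1C(C(=O)OCC2COCCOCCOCCOCCOCCO2)C1(C)C` has not yet been tested in this assay. It keeps the ester of compound 1 and differs in one place (2,2-dimethyl-3-(2-methylprop-1-en-1-yl)cyclopropyl in place of 5-phenylpentyl on a carbonyl carbon). Among the measured compounds shown here, no step between measured compounds has been recorded, so nothing shows how far such a change can move the read-out. Since the two measured values both rest at the limit (the limit of > 100000 nM in this assay, at which 2 of the 2 values shown sit), the expected step from compound 1 to compound 3 in this assay, a step that the limit leaves unreadable from compound 1 to compound 3, is none beyond the usual scatter. Compound 3 is therefore estimated at 150000 nM, with a plausible range from 30000 nM to 1000000 nM, most likely as another limit.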

Compound 3, concentration for 50% growth inhibition: 56000 nM
Beside the measured number, compound 3's estimate is 2.7-fold (0.43 log units) above it; the range from low to high includes it.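

In this assay compound 3 gives 56000 nM, the only actual number among the compounds shown, so a change to the group on this carbonyl carbon can bring growth inhibition within the range the method reads. Compound 1 remains at a limit of the assay, > 100000 nM, and not at a number. The swap of 5-phenylpentyl for 2,2-dimethyl-3-(2-methylprop-1-en-1-yl)cyclopropyl therefore gives only a floor, an at least 1.7-fold lower number from compound 1 to compound 3 (0.25 log units; that floor lies within the scatter), so the true size of the step cannot be read and a real effect of this change is not established: the limit of > 100000 nM in this assay, at which 2 of the 3 values shown sit.

The compounds shown do not separate the parts of the entering group, so it remains open whether a plain cyclopropyl without the methyl groups and the double bond, or a short unbranched butyl chain, would give a readable number at this carbonyl carbon. Also open, as far as these compounds go, is what an amine or a carboxylic acid at the end of the acyl chain would do, and whether an amide in place of the ester would keep the value of compound 3, 56000 nM.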